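From a Methyl Sulfonamide to an Aryl Sulfonamide

The compounds below may be only part of what the source reports. "The series", "measured", "known", "first", "only" and "open" are said of these compounds alone.

The study concerns inhibitors in an assay on cells for inhibition of HSP60/HSP10 (Homo sapiens), with a stated time of 60 min; on this read-out higher numbers stand for weaker inhibition and lower numbers for stronger inhibition. Compound 1 `Cc1ccccc1S(=O)(=O)Nc1ccc(-c2nc3ccccc3o2)cc1` gives 85000 nM and compound 2 `O=S(=O)(Nc1ccc2oc(-c3ccccc3)nc2c1)c1ccc(F)c(C(F)(F)F)c1` gives 69000 nM. Compound 3 `CS(=O)(=O)Nc1ccc2oc(-c3ccccc3)nc2c1` reaches only a limit of the assay, > 100000 nM, and so has no number of its own. It sits at the limit of > 100000 nM in this assay, at which 1 of the 3 values shown sits. Compound 4 `COc1ccc(Cl)cc1S(=O)(=O)Nc1ccc2oc(-c3ccccc3)nc2c1` differs from compound 3 in one place: 5-chloro-2-methoxyphenyl in place of methyl on a sulfonyl sulfur. Among the compounds with values here, no measured pair shows this change, so its size can only be inferred. Since compound 1 gives 85000 nM with an aryl group on the sulfonyl sulfur, compound 4 is expected to land in the weakly measurable region. The estimated at least 1.4-fold lower number from compound 3 to compound 4 (0.15 log units; that floor lies within the scatter) is a modest gain. Compound 4 is estimated at 70000 nM, between 30000 nM and 160000 nM, with a fair chance that only a limit is reported.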

Compound 4, half-maximal inhibitory concentration: > 100000 nM
Compound 4 gave a limit, no number; the forecaster's own chance of this, stated with the estimate: 35%; at least 1.4-fold (0.15 log units) between middle value and limit.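

Compound 3 and compound 4 both stand only at a limit, so the step between them cannot be read: the limit of > 100000 nM in this assay, at which 2 of the 4 values shown sit.

Going by these compounds, whether 5-chloro-2-methoxyphenyl in place of methyl on a sulfonyl sulfur changes inhibition at all stays open.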